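The compounds below may be only part of what the source reports. "The series", "measured", "known", "first", "only" and "open" are said of these compounds alone.

Measured compounds:
Compound 1 `Cc1cccc(S(=O)(=O)Nc2ccc(-c3nc4ccccc4o3)cc2)c1` in an assay on isolated protein for inhibition of malate dehydrogenase, mitochondrial (Sus scrofa), with stated times of 45 min and 30 min (a lower number here means a stronger inhibitor, a higher number a weaker inhibitor), gives > 63000 nM, a limit of the assay rather than a number.
Compound 2 `O=S(=O)(Nc1ccc(-c2nc3ccccc3o2)cc1)c1ccc(Cl)s1` gives > 63000 nM, again a limit.
Compound 3 `Cc1cccc(S(=O)(=O)Nc2ccc3oc(-c4ccccc4)nc3c2)c1` gives > 63000 nM, also a limit.

All three values sit at the limit of > 63000 nM in this assay, at which 3 of the 3 values shown sit, so compound 3 stands at the same limit as the others and cannot be ranked against them. Compound 4 `O=S(=O)(Nc1ccc2oc(-c3ccccc3)nc2c1)c1cccc(F)c1` differs from compound 3 by fluoro in place of methyl on an aromatic carbon. For the measured compounds named here, the only measured step, a step that the two limits leave unreadable from compound 1 to compound 2, runs between two limits and its size cannot be read, so it offers no scale for swapping the ring on the sulfonyl sulfur. With nothing but limits shown, no step beyond the scatter is expected from compound 3 to compound 4; the expected step is a number no higher from compound 3 to compound 4 (the limit leaves the size open). Compound 4 is therefore estimated at 63000 nM, between 20000 nM and 200000 nM, and most likely will again be reported only as a limit.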

Compound 4, half-maximal inhibitory concentration: > 63000 nM
Compound 4 ended at the assay's limit (the forecaster's own chance of this, stated with the estimate: 85%); the middle value sits exactly at the limit.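

For the compounds shown here, compound 3 and compound 4 both give only a limit of the assay, not a number, so no step between them can be read: the limit of > 63000 nM in this assay, at which 4 of the 4 values shown sit.

On these data alone, whether any change to these compounds would give a readable number in this assay remains open.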